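The source may hold more compounds than are shown below. What is called first, only, known or untested is meant among the compounds shown, and "the series" means these compounds.

Working notes on the series. In a functional assay on HepG2 cells (Homo sapiens) for antiproliferative activity, read by MTT assay, with a stated time of 72 h (on this read-out higher numbers stand for weaker inhibition and lower numbers for stronger inhibition), compound 1 `O=c1nc2oc(C3CC3)c(C#CC3CC3)c2cn1Cc1cn(-c2ccccc2F)nn1` gives 39100 nM. Compound 2 `CCCCCCc1cc2cn(Cc3cn(-c4ccccc4F)nn3)c(=O)nc2o1` reaches only the limit of the assay, > 100000 nM, and not a number. Compound 3 `CCCCCc1ccc(C#Cc2c(-c3ccc(CCCCC)cc3)oc3nc(=O)n(Cc4cn(-c5ccc(Cl)cc5)nn4)cc23)cc1` likewise stops at the limit, > 100000 nM. Among the measured compounds shown here, two of the three values shown sit at the limit of > 100000 nM in this assay, at which 2 of the 3 values shown sit; compound 2 is one of them and so stands at the weak end of what is known, compound 1 being the only compound with a measured number.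

Compound 4 `O=c1nc2oc(CCCCl)cc2cn1Cc1cn(-c2ccccc2F)nn1` differs from compound 2 by chloro in place of propyl on a saturated chain carbon, three bonds along the chain from an aromatic carbon; read one bond further out, the hexyl of compound 2 becomes 3-chloropropyl. No step between two measured compounds is shown, so the series gives no direction for this change. The step from compound 2 to compound 4 in this assay is expected to stay within the scatter, an at least 1.1-fold lower number from compound 2 to compound 4 (0.04 log units; that floor lies within the scatter). Compound 4 is therefore expected to give 90000 nM in this assay, between 30000 nM and 300000 nM, with a real chance that only a limit is reported again.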

Compound 4, half-maximal inhibitory concentration: 79800 nM
The estimate for compound 4 lay 1.1-fold (0.05 log units) above the measured number, and the stated range covers the measured number.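

In this assay, chloro in place of propyl on a saturated chain carbon, three bonds along the chain from an aromatic carbon, gives an at least 1.2-fold lower number from compound 2 to compound 4 (0.09 log units; that floor lies within the scatter). Among the compounds shown here, this is the first readable step at this position, and it shows that the 3-chloropropyl chain of compound 4 gives a measured number, but the step is only a floor. Compound 2 stands at a limit of the assay and not at a number, so the full size of the step stays unknown: the limit of > 100000 nM in this assay, at which 2 of the 4 values shown sit.

As far as these compounds go, whether the true step lies beyond the scatter remains open, and compound 1 differs from compound 4 in more than one place, so the two cannot be compared. Also open, from the compounds shown here alone, is how an amine, a carboxylic acid or a longer chlorinated chain in place of the 3-chloropropyl would read in this assay.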